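A few compounds are considered here, and "the series" means these few. Any claim that something is new, unique, unknown or untested is made for them only; others in the source may bear on it.

Measured compounds:
- Compound 1, `COc1cc(C2CC(c3ccc(OCc4cn(Cc5ccc([N+](=O)[O-])cc5)nn4)cc3)=NN2C(C)=O)ccc1Oc1cn(Cc2ccc([N+](=O)[O-])cc2)nn1`, gives 29%
- Compound 2, `COc1cc(C2CC(c3ccccc3)=NN2C(C)=O)ccc1OCc1cn(Cc2ccc([N+](=O)[O-])cc2)nn1`, gives 0%

Both compounds were tested in a functional assay on A549 cells (Homo sapiens) for inhibition, read by sulforhodamine B assay, tested at 10 uM; on this read-out higher numbers stand for more inhibition of growth at the one concentration tested and lower numbers for less inhibition of growth. Compound 2 has the lowest of the two numbers, and it differs from compound 1 in more than one place, so the two values can only be set side by side: compound 1 lies higher, and the gap between them is beyond the usual scatter of repeated measurements.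

Compound 3, `COc1ccc(C2=NN(C(C)=O)C(c3ccc(OCc4cn(Cc5ccc([N+](=O)[O-])cc5)nn4)c(OC)c3)C2)cc1`, has not yet been measured in this assay. It differs from compound 2 in a single place: methoxy in place of hydrogen on an aromatic carbon. The two compounds share everything else, including the core with its acetyl group and the ether carrying the nitrobenzyl-substituted triazole.

Within the data shown here, no pair of measured compounds differing in only one place is available, so the size of this step cannot be read from the data. A methoxy group in place of a hydrogen is a small change, and the expected step from compound 2 to compound 3 is a number 8 percentage points higher from compound 2 to compound 3 (within the scatter), that is, little or no change beyond the scatter, with a slight lean upward only because compound 1 with its larger substituents gives 29%. Compound 3 is therefore estimated to give 8%, with a likely range from 0% to 25%.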

Compound 3, percent growth inhibition at one concentration: 43%
For compound 3 the middle estimate is 35 percentage points below the measured one; the measured number lies above the stated range.
By their numbers in this assay, from the lowest: compound 2; then compound 1; then compound 3.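

In this assay, among these compounds, replacing phenyl with 4-methoxyphenyl gives a number 43 percentage points higher from compound 2 to compound 3 (beyond the scatter), the first change in this set that can be read on its own. It shows that this place, on a six-membered aromatic ring of carbon only and para to a large group, is not indifferent: a small group without a ring or a net charge is enough to move the read-out well beyond the usual scatter, and compound 1 could not show this, as it differs from compound 2 in more than one place. No measurement shown here explains the rise, so the step stands as an observation about growth inhibition and nothing more.

As far as these compounds go, whether the rise belongs to methoxy itself stays open, and an amine, a fluorine atom or a longer chain such as butoxy in the same place would help to show how much depends on the particular group. From the compounds shown here alone, this is also a single step on a single background at one concentration, so it remains unknown whether methoxy would have the same effect on other members or how these compounds would compare across a range of concentrations.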